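A Urea Aryl Swap Toward Compound 3

The source may report more compounds than this note shows. Statements on the series, on what has been measured and on what is new or still open speak of the compounds shown alone.

Compound 1 `CCN(CC)CCCNc1nc(-c2ccc(NC(=O)Nc3ccc(Cl)cc3Cl)cc2)nc2c(Cl)c(Cl)sc12` gives 1230 nM in a functional assay on HT-29 cells (Homo sapiens) for cytotoxicity, read by MTT assay, with a stated time of 72 h; a lower number here means a stronger inhibitor, a higher number a weaker inhibitor.
Compound 2 `CCN(CC)CCNc1nc(-c2ccc(NC(=O)Nc3ccc(F)cc3)cc2)nc2c(Cl)c(Cl)sc12` gives 650 nM in this assay.

Compound 2 has the lowest of the two numbers recorded so far, and the nearest is compound 1, whose number is higher by a margin that stays within the usual scatter of repeated measurements. Nothing more can be read into the order of these two.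

Compound 3 `CCN(CC)CCNc1nc(-c2ccc(NC(=O)Nc3ccc(Cl)cc3Cl)cc2)nc2c(Cl)c(Cl)sc12` is the next compound to be tested. It differs from compound 2 in one place: 2,4-dichlorophenyl in place of 4-fluorophenyl on an amide-type nitrogen. Going by the values given here, no step between two measured compounds isolates this change, so its size cannot be read from the data. The only related point is that compound 1, which also carries a 2,4-dichlorophenyl on that nitrogen, gives 1230 nM, a number within the scatter of compound 2.

On this basis compound 3 is expected to land close to compound 2, with a step of a 1.4-fold higher number from compound 2 to compound 3 (0.14 log units; within the scatter) that is estimated to be small and not clearly beyond the scatter. The estimate for compound 3 in this assay is 900 nM, with a range from 400 nM to 2000 nM.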

Compound 3, half-maximal inhibitory concentration: 1140 nM
The estimate for compound 3 lay 1.3-fold (0.10 log units) below the measured number; the range from low to high includes it.
By their numbers in this assay, from the lowest: compounds 2, 3 and 1 (each within the scatter of the next).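

In this assay the exchange on the amide-type nitrogen can now be read directly: 2,4-dichlorophenyl in place of 4-fluorophenyl gives a 1.8-fold higher number from compound 2 to compound 3 (0.24 log units; within the scatter) and so shows no separable effect on the read-out between these two aryl groups. Going by these compounds alone, the new compound also gives the first readable step at the other end of the molecule, where, with 2,4-dichlorophenyl held constant, diethylamino in place of (diethylamino)methyl on a saturated chain carbon gives a 1.1-fold lower number from compound 1 to compound 3 (0.03 log units; within the scatter) and so likewise shows no separable effect. Neither the aryl exchange nor the chain exchange moves the number beyond the scatter in these compounds, and no measurement is available to explain this result.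

As far as these compounds go, it remains open whether a more different group on the amide-type nitrogen, such as an unsubstituted phenyl or a phenyl carrying a carboxylic acid, would give a step beyond the scatter. From the compounds shown here alone, it is equally open whether a longer chain, or a morpholine in place of diethylamino, would separate from these three compounds, and whether the two exchanges would behave the same way in combination with such groups.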